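From compound 3 to compound 4: half-life in question

The source may report more compounds than this note shows. Statements on the series, on what has been measured and on what is new or still open speak of the compounds shown alone.

Compound 1 `Cn1nncc1-c1cnn([C@H](CC2CC2)c2ccc(-c3c(-n4cnnn4)ccc(Cl)c3F)c[n+]2[O-])c1`: > 3 h (a limit)
Compound 2 `COCC[C@H](c1ccc(-c2c(-n3cnnn3)ccc(Cl)c2F)c[n+]1[O-])n1cc(-c2cnnn2C)cn1`: 2.83 h
Compound 3 `Cn1nncc1-c1cnn([C@H](CCOC(F)F)c2ccc(-c3c(-n4cnnn4)ccc(Cl)c3F)c[n+]2[O-])c1`: > 3.08 h (a limit)

In an ADME assay on microsomes from liver (Homo sapiens) for metabolic stability (a higher number here means that the compound lasts longer, a lower number that the compound disappears faster), compound 3 gives > 3.08 h, which is a limit and not a number.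

Compound 4 `Cn1nncc1-c1cnn([C@H](CCOC(F)F)c2ccc(-c3c(-n4cc(C(F)(F)F)nn4)ccc(Cl)c3F)c[n+]2[O-])c1` differs from it on an aromatic carbon, with 4-(trifluoromethyl)-1H-1,2,3-triazol-1-yl in place of 1H-tetrazol-1-yl on an aromatic carbon.

Among the measured compounds shown here, no measured step touches this place. The nearest evidence comes from changes elsewhere: an at least 1.0-fold lower number from compound 1 to compound 2 (0.02 log units; that floor lies within the scatter) and an at least 1.0-fold higher number from compound 2 to compound 3 (0.03 log units; that floor lies within the scatter), both floors within the scatter, while a step that the two limits leave unreadable from compound 1 to compound 3 gives no readable size.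

With so little to go on, the expected change is no step beyond the scatter, estimated as an at least 1.2-fold lower number from compound 3 to compound 4 (0.09 log units; that floor lies within the scatter).

For compound 4 the estimate is 2.5 h, with an expected range from 1.2 h to 4.5 h.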

Compound 4, half-life: > 3.08 h
Compound 4: only a limit was reported (the forecaster's own chance of this, stated with the estimate: 40%); middle value at least 1.2-fold (0.09 log units) away from the limit.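

Among the compounds shown here, compound 4 gives > 3.08 h, a limit and not a number, and compound 3 also stands at a limit, so no step between them can be read. The compounds shown leave open whether 4-(trifluoromethyl)-1H-1,2,3-triazol-1-yl in place of 1H-tetrazol-1-yl changes the half-life at all.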